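From pyridin-3-yl to 2-methoxyphenyl on a shared core

The source may hold more compounds than are shown below. What is called first, only, known or untested is meant among the compounds shown, and "the series" means these compounds.

Of the compounds shown here, three built on one shared core have been tested in an ADME assay on HEK293 cells (Homo sapiens) for cytotoxicity, read by fluorescence and resazurin assay, with a stated time of 24 h; on this read-out higher numbers stand for lower toxicity in this test and lower numbers for higher toxicity in this test. Compound 1 `Cc1ccc(-c2nnc(SC3=CS(=O)(=O)c4ccccc43)o2)cc1` gives 3000 nM. Compound 2 `O=S1(=O)C=C(Sc2nnc(-c3cccnc3)o2)c2ccccc21` gives 4000 nM, and compound 3 `CC(=O)Nc1ccc(-c2nnc(SC3=CS(=O)(=O)c4ccccc43)o2)cc1` gives 4000 nM. Compound 2 thus stands level with compound 3, the two together at the top of the three numbers, while a 1.3-fold higher number from compound 1 to compound 2 (0.12 log units; within the scatter) is a small move. The other change measured, a 1.3-fold higher number from compound 1 to compound 3 (0.12 log units; within the scatter), is equally small. Compound 4 `COc1ccccc1-c1nnc(SC2=CS(=O)(=O)c3ccccc32)o1` has not yet been measured; it differs from compound 2 by 2-methoxyphenyl in place of pyridin-3-yl on an aromatic carbon. Both measured steps exchanged the group on this same aromatic carbon and shifted the number only within the scatter, so in this assay the expected step is no change at the digits printed from compound 2 to compound 4 (within the scatter), nothing beyond the scatter. Compound 4 is therefore estimated at 4000 nM, in a range from 2000 nM to 8000 nM.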

Compound 4, half-maximal cytotoxic concentration: 3000 nM
Compound 4: the middle estimate sits 1.3-fold (0.12 log units) above what was measured; the range from low to high includes it.
By their numbers in this assay, from the lowest: compounds 1, 4, 2 and 3 (each within the scatter of the next).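

In this assay, exchanging pyridin-3-yl for 2-methoxyphenyl gives a 1.3-fold lower number from compound 2 to compound 4 (0.12 log units; within the scatter), and exchanging 4-methylphenyl for 2-methoxyphenyl gives no change at the digits printed from compound 1 to compound 4 (within the scatter). So at this aromatic carbon, a ring of carbon only in place of a ring with a nitrogen, carrying a methoxy group, still leaves the number within the scatter. Nothing available explains this flat picture. As far as these compounds go, whether an amine or a carboxylic acid on this carbon would move the number beyond the scatter remains open. So does whether any change elsewhere on the shared core would do so.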